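Working notes: bromo in place of chloro, compound 3

The source may report more compounds than this note shows. Statements on the series, on what has been measured and on what is new or still open speak of the compounds shown alone.

Compound 1 `O=[N+]([O-])c1cc(C(F)(F)F)cc([N+](=O)[O-])c1Oc1ccc(Cl)cc1/C=N\OCc1ccccc1Cl`: 5030 nM
Compound 2 `O=[N+]([O-])c1cc(C(F)(F)F)cc([N+](=O)[O-])c1Oc1ccc(Cl)cc1/C=N\OCc1ccc(Cl)cc1Cl`: 3440 nM
Compound 3 `O=[N+]([O-])c1cc(C(F)(F)F)cc([N+](=O)[O-])c1Oc1ccc(Br)cc1/C=N\OCc1ccc(Cl)cc1Cl`: not yet measured

Among the compounds with values here, in a functional assay on A549 cells (Homo sapiens) for antiproliferative activity, read by MTT assay, with a stated time of 48 h (a lower number here means a stronger inhibitor, a higher number a weaker inhibitor), compound 2 gives 3440 nM, and its only comparison is compound 1. The measured step is a 1.5-fold lower number from compound 1 to compound 2 (0.17 log units; within the scatter), which lies within the scatter, so the two cannot be ranked.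

The change to compound 3 is bromo in place of chloro on an aromatic carbon. Within the data shown here, no measured step covers this swap. Among the measured compounds shown here, the single step available is a different change, chloro in place of hydrogen on an aromatic carbon, made elsewhere in the molecule. With only a 1.5-fold lower number from compound 1 to compound 2 (0.17 log units; within the scatter) to go on, no shift beyond the scatter is expected in this assay, and neither direction is favoured. The estimated step is a 1.0-fold lower number from compound 2 to compound 3 (0.02 log units; within the scatter). Compound 3 is expected at 3300 nM, with an estimated range of 1600 nM to 6800 nM.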

Compound 3, half-maximal inhibitory concentration: 2060 nM
Compound 3: the middle estimate sits 1.6-fold (0.20 log units) above what was measured, within the range that was stated.
By their numbers in this assay, from the lowest: compounds 3, 2 and 1 (each within the scatter of the next, the first and the last beyond it).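

Bromo in place of chloro on an aromatic carbon, meta to a large group and para to a large group, gives a 1.7-fold lower number from compound 2 to compound 3 (0.22 log units; within the scatter) in this assay, so the two halogens at this position cannot be ranked. Within the data shown here, this is the first step at this position, since the earlier step was chloro in place of hydrogen at a different place in the molecule, and it shows that this one-atom halogen exchange leaves the result within the scatter. Nothing available explains the result or links it to any property of either halogen.

The compounds shown contain only chloro and bromo at this position, so it remains open whether hydrogen, an amine, a carboxylic acid or a longer chain would shift the number beyond the scatter. As far as these compounds go, whether bromo gives a similar result without the added chloro of compound 2 also remains open.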